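The source may hold more compounds than are shown below. What is called first, only, known or untested is meant among the compounds shown, and "the series" means these compounds.

In a functional assay for inhibition, with Rattus norvegicus as the target (a lower number here means a stronger inhibitor, a higher number a weaker inhibitor), compound 1 `CC(/N=c1\c(O)c(O)\c1=N/c1ccccc1)C(C)(C)C` gives 5400 nM. Compound 2 `CC(/N=c1\c(O)c(O)\c1=N/c1ccc(C#N)cc1)C(C)(C)C`, with cyano in place of hydrogen on an aromatic carbon, gives 520 nM. Compound 3 `CC(/N=c1\c(O)c(O)\c1=N/c1ccc(S(C)(=O)=O)cc1)C(C)(C)C`, with methylsulfonyl on that carbon, is reported only as a limit of the assay, > 30000 nM. Compound 3 therefore has no exact place on the scale, and the steps that reach it are bounds. The steps in this series are a 10-fold lower number from compound 1 to compound 2 (1.02 log units; beyond the scatter), an at least 5.5-fold higher number from compound 1 to compound 3 (0.74 log units; beyond the scatter) and an at least 57-fold higher number from compound 2 to compound 3 (1.76 log units; beyond the scatter).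

Compound 4 `CC(/N=c1\c(O)c(O)\c1=N/c1ccc(-c2ccccc2)cc1)C(C)(C)C` carries phenyl in place of methylsulfonyl on an aromatic carbon, para to a large group (phenyl in place of methylsulfonyl on an aromatic carbon). Among the measured compounds shown here, none of the measured steps involves phenyl, but they show that this carbon can move the number a long way in either direction. With compound 1 at 5400 nM in the middle of that span, a value near it is the most reasonable expectation. Such a value would be a lower number than the limit of compound 3. The expected change is an at least 10-fold lower number from compound 3 to compound 4 (1.00 log units; beyond the scatter). For compound 4 the estimated value is 3000 nM, with an expected range of 400 nM to 25000 nM.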

Compound 4, half-maximal inhibitory concentration: > 30000 nM
Compound 4 gave a limit, no number; the forecaster's own chance of this, stated with the estimate: 15%; middle value at least 10-fold (1.00 log units) from the limit.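

In this assay, phenyl on this aromatic carbon moves the number the opposite way from cyano: an at least 5.5-fold higher number from compound 1 to compound 4 (0.74 log units; beyond the scatter), and an at least 57-fold higher number from compound 2 to compound 4 (1.76 log units; beyond the scatter). Among the compounds shown, cyano is thus the only group that gives a lower number than hydrogen here, while methylsulfonyl and phenyl both give a higher one, so a large change at this carbon can go either way. Compound 3 and compound 4 cannot be put in order, and the step between them cannot be read, because each is reported only as a limit, not a number: the limit of > 30000 nM in this assay, at which 2 of the 4 values shown sit.

On these data alone, whether an amine, a fluorine atom or a carboxylic acid on this carbon would give a number closer to that of compound 2 or end at the limit remains open. As far as these compounds go, how much weaker compound 3 and compound 4 are than the limit shows also remains unknown.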